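Compound 3 to compound 4: hydroxyethyl for hydroxymethyl

This account rests on a few compounds, and the source may have more. Where it says the series, first, only, none or still open, it means among the compounds named here.

In an ADME assay on cells (Hepatocyte, Rattus norvegicus, strain Wistar) for pharmacokinetics, read by LC-MS, with a stated time of 90 min, tested at 1 uM (a lower number here means slower removal, a higher number faster removal of the compound), compound 1 (`CCC1CC(O)C(C)CN1C(=O)c1cc(OC)c2oc(NCc3cccc(Cl)c3)nc2c1`) gives 61.7 mL/min/kg and compound 2 (`COc1cc(C(=O)N2CC(C)CCC2CCO)cc2nc(NCc3cccc(Cl)c3)oc12`) gives 63.3 mL/min/kg; 56.7 mL/min/kg (2 entries). Compound 3 (`COc1cc(C(=O)N2CC(C)OCC2CO)cc2nc(N[C@H](C)c3cccc(Cl)c3)oc12`) has the lowest number at 15.5 mL/min/kg, and the gap up to compound 1, its nearest neighbour, lies beyond the scatter.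

Compound 4 (`COc1cc(C(=O)N2C[C@@H](C)OC[C@H]2CCO)cc2nc(N[C@H](C)c3cccc(Cl)c3)oc12`) differs from compound 3 in one group: 5-(2-hydroxyethyl)-2-methylmorpholin-4-yl in place of 5-(hydroxymethyl)-2-methylmorpholin-4-yl on a carbonyl carbon. This places 5-(2-hydroxyethyl)-2-methylmorpholin-4-yl in place of 5-(hydroxymethyl)-2-methylmorpholin-4-yl on a carbonyl carbon.

Among the measured compounds shown here, no measured pair isolates this change in this assay, so the expectation rests on weak evidence. Compound 2 also carries a 2-hydroxyethyl group and stands at 63.3 mL/min/kg; 56.7 mL/min/kg (2 entries), but it differs from compound 3 elsewhere too, and compound 1 gives a similar number without that group. A small upward step is therefore expected, possibly not beyond the scatter. The estimated step is a 1.4-fold higher number from compound 3 to compound 4 (0.15 log units; within the scatter). For compound 4 the estimated clearance is 22 mL/min/kg, with an expected range of 11 mL/min/kg to 45 mL/min/kg.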

Compound 4, clearance: 38.3 mL/min/kg
For compound 4 the middle estimate is 1.7-fold (0.24 log units) below the measured one; the range from low to high includes it.
By their numbers in this assay, from the lowest: compound 3; then compounds 4 and 1 (each within the scatter of the next).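

In this assay, among the compounds shown here, 5-(2-hydroxyethyl)-2-methylmorpholin-4-yl in place of 5-(hydroxymethyl)-2-methylmorpholin-4-yl on a carbonyl carbon gives the first reading of a single change at this place: a 2.5-fold higher number from compound 3 to compound 4 (0.39 log units; beyond the scatter). Clearance at this place therefore responds to a change in the hydroxyalkyl chain, even with the rest of the molecule held constant. The step is also wider than the spread between repeat readings of a single compound in the series: the several entries of compound 2 in this assay, 63.3 mL/min/kg; 56.7 mL/min/kg (2 entries)

The entering group has 2 defined stereocentres, whereas none are recorded for the leaving group, so chain length and stereochemistry cannot be separated in this step. Also open, as far as these compounds go, is whether a 3-hydroxypropyl chain would raise clearance further, and how an aminomethyl group or a carboxylic acid would behave at this place in this assay.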